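Fluoro in place of hydrogen on compound 3

The source may report more compounds than this note shows. Statements on the series, on what has been measured and on what is new or still open speak of the compounds shown alone.

Compound 1 `CCCC(Oc1ccc2c(c1)c(SC(C)(C)C)c(CC(C)(C)C(=O)O)n2Cc1ccc(Cl)cc1)c1ccc2ccccc2n1`: > 52 nM, a limit and not a number
Compound 2 `CC(C)(C)Sc1c(CC(C)(C)C(=O)O)n(Cc2ccc(Cl)cc2)c2ccc(CCc3ccc4ccccc4n3)cc12`: 4 nM
Compound 3 `CC(C)(C)Sc1c(CC(C)(C)C(=O)O)n(Cc2ccc(Cl)cc2)c2ccc(OCc3ccc4cc(F)ccc4n3)cc12`: 2 nM

All three results come from a functional assay for inhibition, with Homo sapiens as the target; on this read-out higher numbers stand for weaker inhibition and lower numbers for stronger inhibition. Compound 1 is reported only as a limit, > 52 nM. The numerical results are confined to two compounds. Compound 2 gives 4 nM and compound 3 gives 2 nM, and these two values lie within the scatter of each other, so no order can be drawn between them. Compound 3 therefore stands level with compound 2 at the strong end of the values shown.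

The next compound is compound 4 `CC(C)(C)Sc1c(CC(C)(C)C(=O)O)n(Cc2ccc(Cl)cc2)c2ccc(OCc3ccc4cc(F)c(F)cc4n3)cc12`. It differs from compound 3 by fluoro in place of hydrogen on an aromatic carbon. The new fluoro sits on a six-membered aromatic ring of carbon only, part of a fused or bridged system of two rings. It is ortho to a fluoro group, meta to a fused ring and para to a fused ring.

Within the data shown here, no measured pair isolates this change, so the starting point is compound 3 at 2 nM. The expected change in this assay is none beyond the scatter, with an estimated step of a 1.5-fold higher number from compound 3 to compound 4 (0.18 log units; within the scatter). Compound 4 is estimated at 3 nM, with an expected range of 1 nM to 8 nM.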

Compound 4, half-maximal inhibitory concentration: 7 nM
For compound 4 the middle estimate is 2.3-fold (0.37 log units) below the measured one, and the stated range covers the measured number.
By their numbers in this assay, from the lowest: compounds 3, 2 and 4 (each within the scatter of the next, the first and the last beyond it). At a limit, above all of these: compound 1.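

In this assay fluoro in place of hydrogen on this aromatic carbon, ortho to a fluoro group, gives a 3.5-fold higher number from compound 3 to compound 4 (0.54 log units; beyond the scatter) and so moves towards weaker inhibition. Among these compounds, this is the first step that isolates a single change, and it shows that a second fluoro on this six-membered aromatic ring of carbon only costs a modest amount of inhibition, with compound 4 still giving 7 nM in this assay as a measured number and not a limit. Nothing among the measurements shown bears on the cause of this step.

As far as these compounds go, it remains open whether the modest loss belongs to this carbon or to the presence of two fluoro groups together, and a compound with a single fluoro on this carbon, or with a chloro or methoxy group there in place of the new fluoro, would separate these readings. From the compounds shown here alone, it also remains open how far the trend extends, as one step on one ring gives a direction for this change alone and supports no general rule for substitution on this ring.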